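Efficacy in a Thiazole Acetic Acid Series: Pyridyl Variants

The compounds below may be only part of what the source reports. "The series", "measured", "known", "first", "only" and "open" are said of these compounds alone.

Measured compounds and their values:
Compound 1, `COc1cc(-c2nc(C(c3ccc(F)cc3)c3ccc(F)cc3)sc2CC(=O)O)ccn1`: 60%
Compound 2, `CS(=O)(=O)Nc1cccc(-c2nc(C(c3ccc(F)cc3)c3ccc(F)cc3)sc2CC(=O)O)c1`: 80%
Compound 3, `Cc1cc(-c2nc(C(c3ccc(F)cc3)c3ccc(F)cc3)sc2CC(=O)O)cnc1N`: 80%

In an in vitro functional assay on HEK285-7 cells for antagonist activity at prostaglandin D2 receptor 2 (Homo sapiens), read by BRET and beta-arrestin recruitment (a lower number here means a smaller maximal response, a higher number a larger maximal response), compound 3 stands level with compound 2, the two together at the top of the three numbers; the step of a number 20 percentage points higher from compound 1 to compound 3 (beyond the scatter) is beyond the scatter, while no change at the digits printed from compound 2 to compound 3 (within the scatter) is within it. Compound 4 is `Cc1cc(-c2nc(C(c3ccc(F)cc3)c3ccc(F)cc3)sc2CC(=O)O)ccn1`; the change is 2-methylpyridin-4-yl in place of 6-amino-5-methylpyridin-3-yl on an aromatic carbon. The step of a number 20 percentage points higher from compound 1 to compound 3 (beyond the scatter) bears on it, since the group entering resembles the group of compound 1 more than that of compound 3. Compound 4 is therefore expected to give a smaller maximal response, estimated as a number 15 percentage points lower from compound 3 to compound 4 (beyond the scatter). Compound 4 is estimated at 65%, within 50% to 85%.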

Compound 4, largest response reached (reported as efficacy), in percent of the reference or control that the assay uses: 80%
For compound 4 the middle estimate is 15 percentage points below the measured one; the measured number falls inside the stated range.
By their numbers in this assay, from the lowest: compound 1; then compounds 2, 3 and 4 (each within the scatter of the next).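

In this assay the change shows no change at the digits printed from compound 3 to compound 4 (within the scatter) even though 2-methylpyridin-4-yl lacks the amino group and its hydrogen-bond donor, so that amino group is not required for this level of response. There is likewise no change at the digits printed from compound 2 to compound 4 (within the scatter) against 3-(methanesulfonamido)phenyl on the same aromatic carbon. The sharper reading is methyl in place of methoxy, a single change giving a number 20 percentage points higher from compound 1 to compound 4 (beyond the scatter) and tying the lower response of compound 1 to that methoxy group.

From the compounds shown here alone, whether an ethyl group, a chlorine or a dimethylamino group in that place would sit with compound 4 or with compound 1 stays open. No measurement at hand explains these results.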